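The source may hold more compounds than are shown below. What is called first, only, known or untested is meant among the compounds shown, and "the series" means these compounds.

Of the compounds shown here, two that share one core have so far been measured in an ADME assay on the whole organism (Rattus norvegicus, strain Sprague-Dawley) for pharmacokinetics, read by LC-MS, with a stated time of 24 h, at a dose of 1 mg/kg by the intravenous route; a lower number here means less compound in the circulation, a higher number more compound in the circulation at the dose given. Compound 1 `CCN1C(=O)COc2c(CN3CCN(C(C)=O)CC3)cc(Nc3ncc(F)c(-c4ccc(F)cc4OC)n3)cc21` gives 336 ng.h/mL, and compound 2 `CCN1C(=O)COc2c(CN3CCN(S(C)(=O)=O)CC3)cc(Nc3ncc(F)c(-c4ccc(F)cc4OC)n3)cc21` gives 246 ng.h/mL. Going by the values given here, compound 2 therefore stands level with its only measured neighbour, and the one step available is a 1.4-fold lower number from compound 1 to compound 2 (0.14 log units; within the scatter). That step swaps methylsulfonyl in place of acetyl on an amine nitrogen in a ring, while the ring itself stays.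

Compound 3 `CCN(CC)Cc1cc(Nc2ncc(F)c(-c3ccc(F)cc3OC)n2)cc2c1OCC(=O)N2CC` goes further, with this change from compound 2: diethylamino in place of 4-(methylsulfonyl)piperazin-1-yl on a saturated chain carbon bound to an aromatic carbon. In words, diethylamino stands in place of 4-(methylsulfonyl)piperazin-1-yl on a saturated chain carbon bound to an aromatic carbon, so the whole ring leaves. The measured step, a 1.4-fold lower number from compound 1 to compound 2 (0.14 log units; within the scatter), bears on this only loosely, since it never removed the ring. Among the compounds with values here, no measured compound shows what an open chain does here, so the direction is a tentative judgement. A small move towards a lower number in this assay is expected, probably not clearly beyond the scatter. The estimated change is a 1.5-fold lower number from compound 2 to compound 3 (0.19 log units; within the scatter). For compound 3 the expected value is 160 ng.h/mL, with an estimated range of 60 ng.h/mL to 400 ng.h/mL.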

Compound 3, area under the concentration-time curve: 111 ng.h/mL
Compound 3: the middle estimate sits 1.4-fold (0.16 log units) above what was measured; measured number inside the range.
By their numbers in this assay, from the lowest: compound 3; then compounds 2 and 1 (each within the scatter of the next).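

In this assay, going by these compounds alone, the step that removes the ring is the first to go beyond the scatter (a 2.2-fold lower number from compound 2 to compound 3 (0.35 log units; beyond the scatter)), and the comparison with the acetyl-capped compound points the same way (a 3.0-fold lower number from compound 1 to compound 3 (0.48 log units; beyond the scatter)). This position, on a saturated chain carbon bound to an aromatic carbon, therefore responds to the group it carries, although both steps are modest and the earlier exchange of acetyl for methylsulfonyl on the intact ring stayed within the scatter. Nothing given here accounts for this fall in the number.

The compounds shown leave open whether the fall follows from losing the ring itself or simply from replacing a larger group with the smaller diethylamino, since the change from compound 2 to compound 3 does both at once. A piperidin-1-yl or morpholin-4-yl group on the same carbon would keep a ring while dropping the acetyl or methylsulfonyl cap, and dimethylamino or a longer open chain such as dipropylamino would show how far the number follows the size of the open amine.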